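From isobutoxy to benzyloxy: an expected shift in growth inhibition

The source may report more compounds than this note shows. Statements on the series, on what has been measured and on what is new or still open speak of the compounds shown alone.

- Compound 1 `O=C(/C=C/c1ccc(O)cc1)c1c(O)cccc1OCC1CCCCC1` gives > 30000 nM as a limit of the assay
- Compound 2 `CC(C)COc1cccc(O)c1C(=O)/C=C/c1ccc(O)cc1` gives 2600 nM as a number

Among the compounds with values here, compound 2 holds the only true number so far in a functional assay on HCT-15 cells (Homo sapiens) for antiproliferative activity, read by sulforhodamine B assay (on this read-out higher numbers stand for weaker inhibition of growth and lower numbers for stronger inhibition of growth), and so cannot yet be ranked exactly against another value. The result for compound 1 is the limit of > 30000 nM in this assay, at which 1 of the 2 values shown sits, and remains a limit.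

The next compound to consider is compound 3 `O=C(/C=C/c1ccc(O)cc1)c1c(O)cccc1OCc1ccccc1`. The change is phenyl in place of isopropyl on a saturated chain carbon bound to an oxygen on an aromatic ring.

Within the data shown here, one measured step bears on this: an at least 11-fold lower number from compound 1 to compound 2 (1.06 log units; beyond the scatter). It is large. It lies at the same place on the molecule, where isopropyl replaced cyclohexyl. Compound 3 brings a six-membered ring back to that place, but an aromatic one, so that step is only a partial guide. A higher number is therefore expected in this assay, though a smaller move than the measured one. The expected size of the move is a 3.1-fold higher number from compound 2 to compound 3 (0.49 log units; beyond the scatter) here. Compound 3 is expected at 8000 nM, with 2000 nM to 30000 nM as the estimated range.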

Compound 3, concentration for 50% growth inhibition: > 30000 nM
Compound 3: a limit, no number (the forecaster's own chance of this, stated with the estimate: 15%); middle value at least 3.7-fold (0.57 log units) away from the limit.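

In this assay, phenyl in place of isopropyl on a saturated chain carbon bound to an oxygen on an aromatic ring gives an at least 11-fold higher number from compound 2 to compound 3 (1.06 log units; beyond the scatter), so an aromatic six-membered ring at this place fails to keep a measurable growth inhibition, just as the saturated cyclohexyl did. Compound 3 gives > 30000 nM, which is a limit of the assay and not a number. The steps between compound 1 and compound 3 cannot be read, so the two rings cannot be ranked against each other, and isopropyl remains the only group here with a true number: the limit of > 30000 nM in this assay, at which 2 of the 3 values shown sit.

The compounds shown cannot separate the effect of having a ring at this place from the effect of simply having more heavy atoms there, since both ring groups are larger than isopropyl and both end at the limit. A smaller ethyl group, a straight butyl chain or a chain ending in an amine at the same place would help show how far growth inhibition depends on the group attached there.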